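A few compounds are considered here, and "the series" means these few. Any claim that something is new, unique, unknown or untested is made for them only; others in the source may bear on it.

Compound 3 `CC[C@H](C)[C@@H]1C(=O)N[C@H](C2Cc3ccccc3C2)C(=O)N1[C@@H](C(=O)NC)c1cnc(C)cc1C` and compound 1 `CC[C@H](C)[C@@H]1C(=O)N[C@H](C2Cc3ccccc3C2)C(=O)N1[C@@H](C(=O)N1CCOCC1)c1cnc(C)cc1C` share one core and differ only at one spot: morpholin-4-yl in place of methylamino on a carbonyl carbon. In an in vitro ADME assay on microsomes from liver (Rattus norvegicus) for metabolic stability (on this read-out higher numbers stand for fast clearance and lower numbers for slow clearance), compound 3 gives 1 mL.min-1.g-1, and compound 1 gives 1 mL.min-1.g-1, so the step of no change at the digits printed from compound 3 to compound 1 (within the scatter). Compound 2 `CCC(CC)[C@@H]1C(=O)N[C@H](C2Cc3ccccc3C2)C(=O)N1[C@@H](C(=O)NC)c1ccc(C)nc1C` has a different core, and the difference between the two cores is not broken down here; in this assay compound 2 gives 2 mL.min-1.g-1, which lies within the usual scatter of the numbers for compound 1 and compound 3. Compound 4 `CCC(CC)[C@@H]1C(=O)N[C@H](C2Cc3ccccc3C2)C(=O)N1[C@@H](C(=O)N1CCOCC1)c1ccc(C)nc1C` is not yet measured and carries the same change on the core of compound 2: morpholin-4-yl in place of methylamino on a carbonyl carbon. Because the earlier step of no change at the digits printed from compound 3 to compound 1 (within the scatter) stayed flat, the step from compound 2 to compound 4 is expected to be small as well, no change at the digits printed from compound 2 to compound 4 (within the scatter). Compound 4 is therefore estimated at 2 mL.min-1.g-1 in this assay, with a likely range from 1 mL.min-1.g-1 to 4 mL.min-1.g-1.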

Compound 4, intrinsic clearance in microsomes: 1 mL.min-1.g-1
Estimate against measurement, compound 4: 2.0-fold (0.30 log units) above; measured number inside the range.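

In this assay, putting morpholin-4-yl in place of methylamino on the carbonyl carbon gives a 2.0-fold lower number from compound 2 to compound 4 (0.30 log units; within the scatter). Set beside the earlier step, the same change reads alike on the two cores: the same change on two cores in this assay, no change at the digits printed (within the scatter) from compound 3 to compound 1 and a 2.0-fold lower number (0.30 log units; within the scatter) from compound 2 to compound 4, 2.0-fold (0.30 log units) apart, within the scatter of two such steps. This shows that the swap leaves the read-out flat on these two cores, but two pairs cannot show that it would stay flat on any other core, and they do not explain why the numbers hold steady.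

The compounds shown leave open how other groups on the same carbonyl carbon, such as dimethylamino or piperidin-1-yl, a ring without the oxygen of morpholine, would read in this assay. They also leave open whether a longer chain on the amide nitrogen would keep the numbers as they are.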